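Methylamino to dimethylamino at the limit of the assay

The compounds below may be only part of what the source reports. "The series", "measured", "known", "first", "only" and "open" are said of these compounds alone.

Measured so far in a functional assay on SW480 cells (Homo sapiens) for antiproliferative activity, read by MTT assay, with a stated time of 48 h; on this read-out lower numbers stand for stronger inhibition and higher numbers for weaker inhibition:
compound 1 `CCCCCC(CCO)n1cnc2c(Cl)ncnc21`: > 50000 nM (a limit)
compound 2 `CCCCCC(CCO)n1cnc2c(NC)ncnc21`: > 50000 nM (a limit)

Compound 2 gives no number in this assay and stands only at its limit of > 50000 nM on these data. The next change leads to compound 3 `CCCCCC(CCO)n1cnc2c(N(C)C)ncnc21` with methyl in place of hydrogen on a nitrogen on an aromatic ring, methylamino to dimethylamino, methyl in place of hydrogen on a nitrogen on an aromatic ring and the rest of the structure untouched.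

Within the data shown here, one measured step bears on this, and it concerns a different place in the change of group: a step that the two limits leave unreadable from compound 1 to compound 2 with methylamino in place of chloro on an aromatic carbon. It has no readable size. Among the measured compounds shown here, the series so far amounts to the limit of > 50000 nM in this assay, at which 2 of the 2 values shown sit, and gives no direction for a methyl on this nitrogen. No step beyond the scatter is therefore expected in this assay and a further limit is the likeliest report.

The expected step is a number no higher from compound 2 to compound 3 (the limit leaves the size open) and it is an estimate only.

Compound 3 is estimated at 50000 nM with an expected range from 25000 nM to 100000 nM in this assay as the reading to come.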

Compound 3, half-maximal inhibitory concentration: > 50000 nM
Compound 3: a limit, no number (the forecaster's own chance of this, stated with the estimate: 75%); the middle value sits exactly at the limit.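

In this assay compound 3 gives > 50000 nM, a limit and not a number. No step can be read among compound 1, compound 2 and compound 3, because all of them stand at the same limit: the limit of > 50000 nM in this assay, at which 3 of the 3 values shown sit.

The compounds shown leave open whether any of these changes on the shared core affects antiproliferative activity at all.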